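A Chlorophenyl Amide Expected to Remain at the Cytotoxicity Limit

The source may hold more compounds than are shown below. What is called first, only, known or untested is meant among the compounds shown, and "the series" means these compounds.

Compound 3 `Cc1ccc(S(=O)(=O)N[C@@H](CC(=O)NC(C)(C)C)C(=O)NCCNC(=O)c2ccc(F)cc2)cc1` carries a 4-fluorophenyl on a carbonyl carbon. In an ADME assay on HepG2 cells (Homo sapiens) for cytotoxicity (on this read-out higher numbers stand for an effect only at larger amounts of compound and lower numbers for an effect already at smaller amounts), compound 3 gives > 11000 nM, which is a limit of the assay and not a number. Compound 1 `Cc1ccc(S(=O)(=O)N[C@@H](CC(=O)NC(C)(C)C)C(=O)NCCNC(=O)Nc2ccccc2)cc1` has an anilino on that carbonyl carbon, and in this assay compound 1 gives > 11000 nM, again a limit. Compound 2 `Cc1ccc(S(=O)(=O)N[C@@H](CC(=O)NC(C)(C)C)C(=O)NCCNC(=O)c2cc(Cl)ccc2Cl)cc1` carries a 2,5-dichlorophenyl there, and in this assay compound 2 gives > 11000 nM, also a limit. Because (the limit of > 11000 nM in this assay, at which 3 of the 3 values shown sit), the steps a step that the two limits leave unreadable from compound 1 to compound 2, a step that the two limits leave unreadable from compound 1 to compound 3 and a step that the two limits leave unreadable from compound 2 to compound 3 have no readable size; all that can be said is that none of the three aromatic groups on the carbonyl carbon brought the cytotoxicity into the measurable range.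

Compound 4 `Cc1ccc(S(=O)(=O)N[C@@H](CC(=O)NC(C)(C)C)C(=O)NCCNC(=O)c2ccccc2Cl)cc1` differs from compound 3 by 2-chlorophenyl in place of 4-fluorophenyl on a carbonyl carbon. The three measured steps all concern the same place and the same kind of exchange, yet none of them has a readable size, so they give no direction for this change, only the observation that every variant so far sat at the limit. Compound 4 is therefore expected to sit at the limit as well, with a step that the limit leaves unreadable from compound 3 to compound 4 expected only as a nominal figure. The estimate for compound 4 in this assay is 15000 nM, with an expected range from 7000 nM to 40000 nM.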

Compound 4, half-maximal effective concentration: > 11000 nM
Compound 4: no number, only a limit; the forecaster's own chance of this, stated with the estimate: 85%; the middle value is on the limit's open side.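

In this assay compound 4 gives > 11000 nM, again a limit of the assay and not a number. Going by these compounds alone, no step from compound 1, compound 2 or compound 3 to compound 4 can be read, as every value stands at the same limit: the limit of > 11000 nM in this assay, at which 4 of the 4 values shown sit. The compounds shown leave open how these four differ in cytotoxicity, if they differ at all.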